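Longer Branched Chain on an Amine Nitrogen

The compounds below may be only part of what the source reports. "The series", "measured", "known", "first", "only" and "open" are said of these compounds alone.

Of the compounds shown here, two have been measured in a functional assay on the whole organism (blood, strain Wistar-Okamoto) with Rattus norvegicus as the target, with a stated time of 5 days; a higher number here means that more compound is needed for the effect, a lower number that less compound is needed. Compound 1 `CC(C)C(C)(C)/N=C(\NC#N)Nc1ccncc1` gives 20 mg/kg. Compound 2 `Cc1noc(C)c1N/C(=N/C#N)NC(C)(C)C`, built on a different core, gives 10 mg/kg. This is the lower of the two numbers, but the gap to compound 1 lies within the usual scatter, so the two compounds cannot be ranked against each other. Compound 3 `Cc1noc(C)c1N/C(=N/C#N)NC(C)C(C)(C)C` has not yet been measured. It keeps the core of compound 2 and differs from it in a single place: 1,2,2-trimethylpropyl in place of tert-butyl on an amine nitrogen. Among the compounds with values here, no measured pair shows what such a change does in this assay, so there is no step to lean on, and the change touches neither a ring nor a hydrogen-bond donor or acceptor. The expected step of a 1.5-fold higher number from compound 2 to compound 3 (0.18 log units; within the scatter) is therefore small, in no clear direction, and likely within the scatter. For compound 3 the estimate in this assay is 15 mg/kg, with a range from 5 mg/kg to 45 mg/kg.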

Compound 3, minimum effective dose: 20 mg/kg
Estimate against measurement, compound 3: 1.3-fold (0.12 log units) below; the range from low to high includes it.
By their numbers in this assay, from the lowest: compounds 2, 1 and 3 (each within the scatter of the next).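

Within the data shown here, this is the first pair in this assay that differs in one place only, so a change on this amine nitrogen can now be read directly. Putting 1,2,2-trimethylpropyl in place of tert-butyl gives a 2.0-fold higher number from compound 2 to compound 3 (0.30 log units; within the scatter) and so does not separate the two groups, which shows that this position can carry the longer branched chain without a step beyond the scatter. Nothing measured here bears on the reason for this result.

From the compounds shown here alone, both groups are branched carbon chains without a ring, so what a cyclohexyl ring or a chain ending in an amine would do on this nitrogen stays open. This single pair also leaves open whether the same change would read alike on another core.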